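The source may hold more compounds than are shown below. What is called first, only, known or untested is meant among the compounds shown, and "the series" means these compounds.

Measured so far in a functional assay on K562 cells (Homo sapiens) for antiproliferative activity, read by MTT assay, with a stated time of 72 h; a lower number here means a stronger inhibitor, a higher number a weaker inhibitor:
- compound 1 `COc1cc(C(=O)c2sc3ccccc3c2-c2ccccc2)cc(OC)c1OC` gives 2100 nM
- compound 2 `COc1cc(C(=O)c2sc3ccccc3c2-c2ccc(F)cc2)cc(OC)c1OC` gives 2100 nM

Compound 2 stands level with compound 1, the only other measured compound, at the digits shown. Compound 3 `COc1cc(C(=O)c2sc3ccccc3c2-c2ccc(Cl)cc2)cc(OC)c1OC` is the next in the series. It has chloro in place of fluoro on an aromatic carbon (4-fluorophenyl to 4-chlorophenyl, para to a large group). Among the compounds with values here, one measured step bears on this change: no change at the digits printed from compound 1 to compound 2 (within the scatter), with fluoro in place of hydrogen on an aromatic carbon, and that step stays within the scatter. Within the data shown here, no chloro compound has been measured yet, so this single step is thin support. A step beyond the scatter is therefore not expected in this assay, and no direction is favoured. The estimated step is no change at the digits printed from compound 2 to compound 3 (within the scatter) and is expected to stay within the scatter. Compound 3 is expected at 2100 nM (estimated range 850 nM to 5000 nM).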

Compound 3, half-maximal inhibitory concentration: 4200 nM
For compound 3 the middle estimate is 2.0-fold (0.30 log units) below the measured one; the range from low to high includes it.
By their numbers in this assay, from the lowest: compounds 1, 2 and 3 (each within the scatter of the next).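

Working through this assay, chloro now joins fluoro at this place, on an aromatic carbon para to a large group, and the step of a 2.0-fold higher number from compound 2 to compound 3 (0.30 log units; within the scatter) is joined by a 2.0-fold higher number from compound 1 to compound 3 (0.30 log units; within the scatter), so neither halogen step leaves the scatter. Hydrogen, fluoro and chloro at this position therefore cannot be told apart in this assay, which extends the earlier single fluoro step to a second halogen and to a second comparison with the unsubstituted phenyl compound. Nothing available here accounts for these numbers.

Going by these compounds, whether a methoxy group, an amine, a carboxylic acid or a longer alkyl chain at this place would give a step beyond the scatter remains open. The series shown also leaves open how changes elsewhere on the shared core would read in this assay, since all three compounds differ only at this one position.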